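A few compounds are considered here, and "the series" means these few. Any claim that something is new, unique, unknown or untested is made for them only; others in the source may bear on it.

The series rests on a shared core, seen in compound 1 `CCC(CC)O[C@@H]1C=C(C(=O)O)C[C@H](NCc2cccc(OC)c2)[C@H]1NC(C)=O`, and was tested in an ADME assay on cells (Fibroblast, Gallus gallus) for cytotoxicity, read by CCK-8 assay, with a stated time of 48 h; a lower number here means that less compound is tolerated, a higher number that more compound is tolerated. For compound 1 the result is a limit of the assay, > 200000 nM. Compound 2 `CCC(CC)Oc1ccc(CN[C@H]2CC(C(=O)O)=C[C@@H](OC(CC)CC)[C@@H]2NC(C)=O)cc1` carries a (pentan-3-yl)oxy group on the aromatic ring; in this assay compound 2 also gives only a limit, > 200000 nM. Compound 3 `CCC(CC)O[C@@H]1C=C(C(=O)O)C[C@H](NCc2cccc(-c3ccc(SC)cc3)c2)[C@H]1NC(C)=O` likewise stops at a limit in this assay, > 200000 nM. Among the compounds with values here, the one single-point step among the measured compounds, a step that the two limits leave unreadable from compound 1 to compound 3, cannot be read because of the limit of > 200000 nM in this assay, at which 3 of the 3 values shown sit, and the same holds for where compound 2 stands: its value is a limit and no number, as are both other values shown.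

Compound 4 `CCC(CC)O[C@@H]1C=C(C(=O)O)C[C@H](NCc2ccc(-c3ccc4sccc4c3)cc2)[C@H]1NC(C)=O` is the unmeasured member. It differs from compound 2 by 1-benzothiophen-5-yl in place of (pentan-3-yl)oxy on an aromatic carbon. Within the data shown here, no measured step bears directly on this change; the only measured step is unreadable, and every value shown sits at the same limit. Compound 4 is therefore expected to stay at or near that limit, with a step of a number no higher from compound 2 to compound 4 (the limit leaves the size open) that is expected to be none beyond the scatter. For compound 4 the estimate in this assay is 200000 nM, expected to fall between 80000 nM and 500000 nM.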

Compound 4, half-maximal cytotoxic concentration: > 200000 nM
Compound 4: only a limit was reported; the forecaster's own chance of this, stated with the estimate: 75%; the middle value lies on the limit itself.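

In this assay compound 4 gives > 200000 nM as a limit and not a number. No new step can be read from compound 2 to compound 4 because both values are limits: the limit of > 200000 nM in this assay, at which 4 of the 4 values shown sit. The compounds shown leave open how much of any of them is tolerated and whether 1-benzothiophen-5-yl in place of (pentan-3-yl)oxy changes that.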